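From chloro to fluoro: one small swap on compound 1

The source may hold more compounds than are shown below. What is called first, only, known or untested is meant among the compounds shown, and "the series" means these compounds.

- Compound 1 `COc1cc(OC)c(OC)cc1/C=C/C(=O)c1ccc(Cl)cc1`: 2.01 ug/mL
- Compound 2 `COc1cc(OC)c(OC)cc1/C=C/C(=O)c1ccc(O)cc1O`: 2.76 ug/mL

In a functional assay, read by Griess assay, with a stated time of 2.5 h (a lower number here means a stronger inhibitor, a higher number a weaker inhibitor), compound 1 gives 2.01 ug/mL. Only compound 2 has been measured alongside it, and the two values lie within the scatter of each other.

Compound 3 `COc1cc(OC)c(OC)cc1/C=C/C(=O)c1ccc(F)cc1` is not yet measured. It differs from compound 1 in one place: fluoro in place of chloro on an aromatic carbon. This is fluoro in place of chloro on an aromatic carbon, para to a large group.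

Among the compounds with values here, the one measured step, a 1.4-fold higher number from compound 1 to compound 2 (0.14 log units; within the scatter), puts 2,4-dihydroxyphenyl in place of 4-chlorophenyl. Within the data shown here, no measured step changes only the halogen, so this is the sole guide, and it stayed within the scatter. No step beyond the scatter is therefore expected in this assay, and no direction can be favoured.

The estimated step is a 1.1-fold higher number from compound 1 to compound 3 (0.04 log units; within the scatter). For compound 3 the expected value is 2.2 ug/mL, with an estimated range of 1.1 ug/mL to 4.4 ug/mL.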

Compound 3, half-maximal inhibitory concentration: 1.96 ug/mL
Beside the measured number, compound 3's estimate is 1.1-fold (0.05 log units) above it; the measured number falls inside the stated range.
By their numbers in this assay, from the lowest: compounds 3, 1 and 2 (each within the scatter of the next).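

Within the data shown here, this is the first step that changes only the halogen: in this assay it reads a 1.0-fold lower number from compound 1 to compound 3 (0.01 log units; within the scatter) and so, on this aromatic carbon para to a large group, chloro and fluoro cannot be told apart. Putting 4-fluorophenyl in place of 2,4-dihydroxyphenyl gives a 1.4-fold lower number from compound 2 to compound 3 (0.15 log units; within the scatter) and so all three groups tried at this end of the shared core lie within the scatter of one another. No outside measurement bears on this result, and the data give no reason for it.

The compounds shown carry only halogens and hydroxyl groups at this end, so it remains open whether an amine, a carboxylic acid or a longer chain such as butoxy would also stay within the scatter. Also open, on these data alone, is what happens when the methoxy groups of the shared core are replaced, for example by ethoxy groups.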